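The source may report more compounds than this note shows. Statements on the series, on what has been measured and on what is new or still open speak of the compounds shown alone.

Compound 1, `O=S(=O)(NCCNCc1cccc2ccccc12)c1cc(C(F)(F)F)cc(C(F)(F)F)c1`: 26000 nM
Compound 2, `O=S(=O)(NCCCNCc1ccc(Cl)c(C(F)(F)F)c1)c1cc(C(F)(F)F)cc(C(F)(F)F)c1`: 7400 nM
Compound 3, `O=S(=O)(NCCCCCCNCc1ccc(Br)cc1)c1ccccc1F`: 13300 nM

In a functional assay on MIA PaCa-2 cells (Homo sapiens) for inhibition, read by MTT assay, with a stated time of 72 h (on this read-out higher numbers stand for weaker inhibition of growth and lower numbers for stronger inhibition of growth), compound 2 gives the lowest of the three numbers. Compound 3 lies within the usual scatter of compound 2, so the two cannot be set in order; compound 1 lies beyond the scatter, with the higher number of the pair.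

Compound 4, `COc1ccc(CNCCCNS(=O)(=O)c2cc(C(F)(F)F)cc(C(F)(F)F)c2)cc1`, differs from compound 2 in one place: 4-methoxyphenyl in place of 4-chloro-3-(trifluoromethyl)phenyl on a saturated chain carbon bound to an amine nitrogen. No comparable exchange exists between any two measured compounds, so there is nothing in this set that shows how such a change moves the read-out. Within the data shown here, the only guide is that the three measured compounds, with quite different aryl groups at the corresponding end of the molecule, all fall within a narrow band. On that basis the step from compound 2 to compound 4 is expected to be small, perhaps a slight rise, and likely within the scatter: a 1.6-fold higher number from compound 2 to compound 4 (0.21 log units; within the scatter). Compound 4 is therefore estimated at 12000 nM, with a range from 4500 nM to 32000 nM.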

Compound 4, concentration for 50% growth inhibition: 2500 nM
Beside the measured number, compound 4's estimate is 4.8-fold (0.68 log units) above it; measured number outside the range, below it.
By their numbers in this assay, from the lowest: compound 4; then compounds 2, 3 and 1 (each within the scatter of the next, the first and the last beyond it).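

In this assay, the exchange of 4-chloro-3-(trifluoromethyl)phenyl for 4-methoxyphenyl on a saturated chain carbon bound to an amine nitrogen gives a 3.0-fold lower number from compound 2 to compound 4 (0.47 log units; beyond the scatter), a step beyond the scatter. This is the only step shown in which the aryl group alone changes, and it shows that the read-out at this position responds to that group. The entering group has fewer heavy atoms and carries a hydrogen-bond acceptor, yet no measurement here bears on why the number falls.

The compounds shown leave open whether the step follows from gaining the methoxy group or from losing the chlorine and trifluoromethyl groups, a question that an unsubstituted phenyl or a 4-hydroxyphenyl at this place would help to separate. They also leave open whether the same exchange would hold on a longer chain.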